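A few compounds are considered here, and "the series" means these few. Any claim that something is new, unique, unknown or untested is made for them only; others in the source may bear on it.

In an ADME assay on HEK293 cells (Homo sapiens) for inhibition, read by MTT assay, with stated times of 18 h and 4 h (on this read-out higher numbers stand for weaker inhibition and lower numbers for stronger inhibition), compound 1 `CCCCCCCCOP(=O)(O)OCCSC(=S)N1CCCC1` gives 28300 nM as the lowest of the two actual numbers in this small set. Compound 2 `CCCCCCCCOP(=O)(O)OCCSC(=S)N1CCN(C)CC1` stands at 86000 nM and so reads higher. Compound 3 `CCCCCCCCOP(=O)(O)OCCSC(=S)N1CCCCCC1` shows > 100000 nM as a limit of the assay and not a number. Compound 4 `CCCOP(=O)(O)OCCSC(=S)N1CCCC1` has not been measured; it keeps the pyrrolidin-1-yl group of compound 1 and alters the chain, with hydrogen in place of pentyl on a saturated chain carbon, three bonds along the chain from an oxygen on an unsaturated carbon as the counted difference: hydrogen in place of pentyl on a saturated chain carbon, three bonds along the chain from an oxygen on an unsaturated carbon. Among the measured compounds shown here, no measured step touches this chain. The nearest guides replace pyrrolidin-1-yl on the thiocarbonyl carbon, giving a 3.0-fold higher number from compound 1 to compound 2 (0.48 log units; beyond the scatter) and an at least 3.5-fold higher number from compound 1 to compound 3 (0.54 log units; beyond the scatter) as steps beyond the scatter. Compound 1 sits lowest at 28300 nM and both steps away from it end higher, so a rise of similar size in this assay is expected, though only as a rough scale. The estimated change is a 2.8-fold higher number from compound 1 to compound 4 (0.45 log units; beyond the scatter) on this reasoning. The expected value for compound 4 is 80000 nM with an estimated range from 28000 nM to 200000 nM overall.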

Compound 4, half-maximal inhibitory concentration: > 100000 nM
Compound 4: no number, only a limit; the forecaster's own chance of this, stated with the estimate: 45%; middle value at least 1.2-fold (0.09 log units) from the limit.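

Among the compounds shown here, this change gives the first view of the chain, since the earlier compounds differ only in the group on the thiocarbonyl carbon. In this assay, hydrogen in place of pentyl gives an at least 3.5-fold higher number from compound 1 to compound 4 (0.54 log units; beyond the scatter), so the low number of compound 1 depends on the pentyl part as well as on its pyrrolidin-1-yl group. The reading for compound 4 is a limit of the assay and not a number, so the step gives only a floor and its full size stays unknown: the limit of > 100000 nM in this assay, at which 2 of the 4 values shown sit.

The compounds shown leave open whether a longer chain, such as dodecyl in place of pentyl, would take the number lower than in compound 1. They also leave open how an amine or a carboxylic acid in place of pentyl would read, and whether butyl would already give most of the rise.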